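Dihydropyridine aryl ethers: from oxadiazole to an acid hydrazide chain

The compounds below may be only part of what the source reports. "The series", "measured", "known", "first", "only" and "open" are said of these compounds alone.

Compound 3 `CCOC(=O)C1=C(C)NC(C)=C(C(=O)OCC)C1c1ccc(OCc2nnc(S)o2)cc1` gives 54.5% in a functional assay on the whole organism (strain Wistar) for inhibition, with Rattus norvegicus as the target, read by paw edema, with stated times of 30 min and 1 h, at a dose of 20 mg/kg; on this read-out higher numbers stand for more inhibition at the one dose given (going by the name of the read-out) and lower numbers for less inhibition. It stands second highest of the three measured compounds: compound 1 `CCOC(=O)C1=C(C)NC(C)=C(C(=O)OCC)C1c1ccc(OCC(=O)Nc2ccc(C)cc2)cc1` gives 55.1% and compound 2 `CCOC(=O)C1=C(C)NC(C)=C(C(=O)OCC)C1c1ccc(OCC(=O)NNC(=O)c2ccccc2)cc1` gives 29.5%, so compound 3 and compound 1 lie within the scatter of each other while compound 2 sits clearly lower. Compound 4 `CCOC(=O)C1=C(C)NC(C)=C(C(=O)OCC)C1c1ccc(OCC(=O)NNC(=O)CCC(=O)O)cc1` differs from compound 3 by a group of 11 heavy atoms (5 carbon, 2 nitrogen, 4 oxygen; no ring) in place of a group of 6 heavy atoms (2 carbon, 2 nitrogen, 1 oxygen, 1 sulfur; one five-membered aromatic ring with 3 hetero atoms), on a saturated chain carbon bound to an oxygen on an aromatic ring. The relevant measured step is a number 25 percentage points higher from compound 2 to compound 3 (beyond the scatter), which shows that replacing a hydrazide-type chain by the oxadiazole raised inhibition modestly; compound 4 reverses that direction with a chain of the hydrazide type. A modest drop is therefore expected, a number 19.5 percentage points lower from compound 3 to compound 4 (beyond the scatter). Compound 4 is estimated at 35%, with a range from 20% to 50%.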

Compound 4, a percentage reported as inhibition, in the whole organism at one dose (the size of the read-out at that dose, not a potency): 43%
Compound 4: middle estimate off by 8 percentage points, on the low side; the range from low to high includes it.
By their numbers in this assay, from the lowest: compound 2; then compound 4; then compounds 3 and 1 (each within the scatter of the next).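

With the hydrazide-type chain kept, 2-carboxyethyl in place of phenyl on a carbonyl carbon gives a number 13.5 percentage points higher from compound 2 to compound 4 (beyond the scatter) in this assay, so the group on that carbon also affects inhibition. The chain still falls short of 5-sulfanyl-1,3,4-oxadiazol-2-yl, with a number 11.5 percentage points lower from compound 3 to compound 4 (beyond the scatter), and of the 4-methylphenyl amide, with a number 12.1 percentage points lower from compound 1 to compound 4 (beyond the scatter). Nothing available explains these steps. As far as these compounds go, it remains open whether an amine or a longer chain in place of 2-carboxyethyl would bring inhibition level with the oxadiazole.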